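A few compounds are considered here, and "the series" means these few. Any claim that something is new, unique, unknown or untested is made for them only; others in the source may bear on it.

In a physicochemical assay for solubility, in phosphate buffer, at pH 7.4 (on this read-out lower numbers stand for lower solubility and higher numbers for higher solubility), compound 2 `OC1CN(c2nccnc2OC2CN(c3ccc4ccccc4n3)C2)C1` gives 41000 nM, the lower of the two numbers measured. Compound 1 `OCC1CCN(c2cccnc2OC2CN(c3ccc4ccccc4n3)C2)CC1` gives 189000 nM, which lies beyond the scatter above it. Compound 3 `c1ccc2nc(N3CC(Oc4nccnc4N4CCCCC4)C3)ccc2c1` stands at < 1000 nM, which is a limit and not a number.

Compound 4 `c1ccc(-c2nccnc2OC2CN(c3ccc4ccccc4n3)C2)cc1` differs from compound 2 by phenyl in place of 3-hydroxyazetidin-1-yl on an aromatic carbon, next to the ring nitrogen. Among the measured compounds shown here, only one measured step removes the same group from the same place. It is an at least 41-fold lower number from compound 2 to compound 3 (1.61 log units; beyond the scatter), with piperidin-1-yl in place of 3-hydroxyazetidin-1-yl, a large step beyond the scatter that ends at a limit. Phenyl is a different group, so this single step is only a rough guide. Resting on an at least 41-fold lower number from compound 2 to compound 3 (1.61 log units; beyond the scatter), a large step to a lower number is expected in this assay. The estimated change is a 59-fold lower number from compound 2 to compound 4 (1.77 log units; beyond the scatter). Compound 4 is expected at 700 nM, within an estimated range of 150 nM to 4000 nM.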

Compound 4, solubility: < 1000 nM
Compound 4: a limit, no number; the forecaster's own chance of this, stated with the estimate: 70%; the middle value is on the limit's open side.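

In this assay, phenyl in place of 3-hydroxyazetidin-1-yl gives an at least 41-fold lower number from compound 2 to compound 4 (1.61 log units; beyond the scatter), so at this aromatic carbon, next to the ring nitrogen, a large step down is no longer tied to piperidin-1-yl alone. Compound 4 gives < 1000 nM, which is a limit and not a number. The step between compound 3 and compound 4 cannot be read, and the two replacements cannot be ranked, as both compounds stand at one limit: the limit of < 1000 nM in this assay, at which 2 of the 4 values shown sit.

As far as these compounds go, how far compound 3 and compound 4 lie beyond that limit remains open. Also open, from the compounds shown here alone, is whether a different group at this place, such as a carboxylic acid, a simple amine or azetidin-1-yl without its hydroxyl, would keep the read-out near that of compound 2.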